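The source may report more compounds than this note shows. Statements on the series, on what has been measured and on what is new or still open speak of the compounds shown alone.

Of the compounds shown here, three sharing one core have been measured in a functional assay on cardiac atrium for antagonist activity at histamine H2 receptor (Cavia porcellus), tested at 0.3 uM; a higher number here means a more potent compound, by a factor of ten per unit of this negative logarithm, a lower number a less potent compound. Compound 1 `N#CN/C(=N\CCNc1ccc(N=[N+]=[N-])cc1[N+](=O)[O-])NCCCCOc1cccc(CN2CCCCC2)c1` gives 7.47. Compound 2 `N#CN/C(=N\CCCNC(=O)c1ccccc1)NCCCOc1cccc(CN2CCCCC2)c1` gives 7.14. Compound 3 `N#CN/C(=N\CCNC(=O)c1ccc(N=[N+]=[N-])cc1)NCCCCOc1cccc(CN2CCCCC2)c1` gives 7.54. Compound 3 holds the highest of the three numbers, but its nearest neighbour, compound 1, sits within the scatter of it, so no order between those two can be claimed; compound 2 lies further off, beyond the scatter. Going by the values given here, the only step between measured compounds that differ in a single place runs a number 0.07 log units higher from compound 1 to compound 3 (within the scatter), a change on an amine nitrogen that left the number where it was.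

Compound 4 `N#CN/C(=N\CCNC(=O)c1ccc(N)cc1)NCCCCOc1cccc(CN2CCCCC2)c1` has not yet been measured. It differs from compound 3 in one place: amino in place of azido on an aromatic carbon. Among the compounds with values here, no measured step exchanges these two groups, so the sole guidance is that the one recorded alteration at this end of the molecule, from compound 1 to compound 3, stayed within the scatter. On that basis compound 4 is expected to show a step of a number 0.24 log units lower from compound 3 to compound 4 (within the scatter), not expected to exceed the scatter in either direction. For compound 4 the estimate in this assay is 7.3, with a range from 6.8 to 7.8.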

Compound 4, negative logarithm of the antagonist equilibrium constant: 7.17
Compound 4: the middle estimate sits 0.13 log units above what was measured, within the range that was stated.
By their numbers in this assay, from the lowest: compounds 2, 4, 1 and 3 (each within the scatter of the next, the first and the last beyond it).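

In this assay, going by these compounds alone, the step of a number 0.37 log units lower from compound 3 to compound 4 (beyond the scatter) is the first single-place change here to pass the scatter, so the group on an aromatic carbon para to a large group does register in this number, which the earlier step of a number 0.07 log units higher from compound 1 to compound 3 (within the scatter) did not show. The exchange is a modest one and alters two counted features together, since azido has three heavy atoms and no hydrogen-bond donor while amino has one heavy atom and one hydrogen-bond donor, and this single pair cannot say which of the two matters. The step of a number 0.30 log units lower from compound 1 to compound 4 (within the scatter) gives no separate reading of this position, as it replaces a whole group on the amine nitrogen and stays inside what repeated measurements would scatter by.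

As far as these compounds go, whether the number follows the loss of azido or the arrival of amino stays open, and a hydrogen, a hydroxyl or a methyl group on the same carbon would be needed to tell these apart. Nothing among the data given speaks to why the number moved.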